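A phenol for two methoxy groups on a nucleoside

The source may report more compounds than this note shows. Statements on the series, on what has been measured and on what is new or still open speak of the compounds shown alone.

Compound 3 `COc1ccc(CNc2ncnc3c2ncn3[C@@H]2O[C@H](CO)[C@@H](O)[C@H]2O)c(OC)c1` gives 39000 nM in a functional assay on HL-60 cells (Homo sapiens) for antiproliferative activity, with a stated time of 72 h (on this read-out higher numbers stand for weaker inhibition and lower numbers for stronger inhibition), the highest of the two numbers shown; compound 1 `OC[C@H]1O[C@@H](n2cnc3c(NCc4ccc(Cl)cc4)ncnc32)[C@H](O)[C@@H]1O` gives 1700 nM, and a 23-fold higher number from compound 1 to compound 3 (1.36 log units; beyond the scatter). Compound 2 `Cc1ccc(CNc2ncnc3c2ncn3[C@@H]2O[C@H](CO)[C@@H](O)[C@H]2O)cc1` reaches only the assay limit of > 166000 nM. That limit is the limit of > 166000 nM in this assay, at which 1 of the 3 values shown sits. Compound 4 `Cc1ccc(O)c(CNc2ncnc3c2ncn3[C@@H]2O[C@H](CO)[C@@H](O)[C@H]2O)c1` carries 2-hydroxy-5-methylphenyl in place of 2,4-dimethoxyphenyl on a saturated chain carbon bound to a nitrogen on an aromatic ring. The measured steps that bear on this change are a 23-fold higher number from compound 1 to compound 3 (1.36 log units; beyond the scatter) and an at least 4.2-fold lower number from compound 2 to compound 3 (0.62 log units; beyond the scatter), both beyond the scatter, showing that the substituents on this ring move the read-out widely. Compound 4 is expected to shift by a 1.5-fold higher number from compound 3 to compound 4 (0.19 log units; within the scatter), a modest weakening, since a methyl-bearing ring returns while the measured at least 4.2-fold lower number from compound 2 to compound 3 (0.62 log units; beyond the scatter) ran the other way. Compound 4 is therefore estimated at 60000 nM, between 15000 nM and 200000 nM.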

Compound 4, half-maximal inhibitory concentration: 15000 nM
Estimate against measurement, compound 4: 4.0-fold (0.60 log units) above; low and high end bracket the measured number.
By their numbers in this assay, from the lowest: compound 1; then compound 4; then compound 3. At a limit, above all of these: compound 2.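

In this assay, the 2-hydroxy-5-methylphenyl ring improves on the 2,4-dimethoxyphenyl ring, with a 2.6-fold lower number from compound 3 to compound 4 (0.41 log units; beyond the scatter). It also gives an at least 11-fold lower number from compound 2 to compound 4 (1.04 log units; beyond the scatter), so a methyl-bearing ring need not sit at the top of the range, yet the 4-chlorophenyl ring stays ahead, with an 8.8-fold higher number from compound 1 to compound 4 (0.95 log units; beyond the scatter). Compound 2 carries a limit, not a number: the limit of > 166000 nM in this assay, at which 1 of the 4 values shown sits.

The compounds shown leave open whether the hydroxy group alone accounts for the gain, as the two rings differ in more than one substituent. They also leave open how an amine or a carboxylic acid on this ring would read.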